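Losing the dimethylamino group from a side chain

A few compounds are considered here, and "the series" means these few. Any claim that something is new, unique, unknown or untested is made for them only; others in the source may bear on it.

Within the data shown here, in a functional assay on Raji cells (Homo sapiens) for antiproliferative activity, read by MTT assay, with a stated time of 48 h (on this read-out lower numbers stand for stronger inhibition and higher numbers for weaker inhibition), compound 2 `CN(C)CCn1c(N)c(-c2nc3ccccc3[nH]2)c2nc(C#N)c(C#N)nc21` gives 8320 nM as the only exact number among the three compounds measured. Compound 1 `CCn1c(N)c(-c2nc3ccccc3[nH]2)c2nc(C#N)c(C#N)nc21` gives > 50000 nM as a limit of the assay. Compound 3 `CN1CCN(CCn2c(N)c(-c3nc4ccccc4[nH]3)c3nc(C#N)c(C#N)nc32)CC1` gives > 50000 nM as the same kind of limit.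

Compound 4 `CCCn1c(N)c(-c2nc3ccccc3[nH]2)c2nc(C#N)c(C#N)nc21` has not been measured and differs from compound 2 in one place: methyl in place of dimethylamino on a saturated chain carbon, two bonds along the chain from an aromatic nitrogen with methyl in place of dimethylamino on a saturated chain carbon, two bonds along the chain from an aromatic nitrogen, so 2-(dimethylamino)ethyl becomes propyl.

Among the measured compounds shown here, two measured steps bear on this change. Putting dimethylamino on the chain gave an at least 6.0-fold lower number from compound 1 to compound 2 (0.77 log units; beyond the scatter) while exchanging it for 4-methylpiperazin-1-yl gave an at least 6.0-fold higher number from compound 2 to compound 3 (0.77 log units; beyond the scatter) and both sizes rest on limits. Removing dimethylamino should largely undo the first of these steps. A move to a higher number in this assay is therefore expected, beyond the scatter, and the estimated change is a 6.0-fold higher number from compound 2 to compound 4 (0.78 log units; beyond the scatter) overall. The estimate for compound 4 is 50000 nM with an expected range from 20000 nM to 100000 nM and the assay may well report only a limit.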

Compound 4, half-maximal inhibitory concentration: > 50000 nM
Compound 4: no number, only a limit; the forecaster's own chance of this, stated with the estimate: 75%; the middle value lies on the limit itself.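

In this assay compound 4 gives > 50000 nM, which is a limit of the assay and not a number. Methyl in place of dimethylamino on this chain gives an at least 6.0-fold higher number from compound 2 to compound 4 (0.77 log units; beyond the scatter), so the plain propyl chain does not keep what the 2-(dimethylamino)ethyl chain gave, though compound 3, which also carries an amine, shows that an amine alone is not enough. The steps linking compounds 1, 3 and 4 to one another cannot be read, because all three stop at the same value: the limit of > 50000 nM in this assay, at which 3 of the 4 values shown sit.

From the compounds shown here alone, how far compounds 1, 3 and 4 really lie from compound 2 stays unknown. Also open, going by these compounds, is whether other groups on this chain, such as a primary amine, diethylamino or a hydroxyl group, would give a measurable number.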